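Bromo in place of tert-butyl: compound 2 to compound 4

A few compounds are considered here, and "the series" means these few. Any claim that something is new, unique, unknown or untested is made for them only; others in the source may bear on it.

The series is followed in an ADME assay on TERT-RPE1 cells (Homo sapiens) for cytotoxicity, read by MTT assay, with a stated time of 72 h; a higher number here means a weaker inhibitor, a lower number a stronger inhibitor. Compound 1 `C=C1CN/C(=N/c2ccccc2)S1` gives only a limit in this assay, > 100000 nM. Compound 2 `COc1ccc(/C=C2\S/C(=N\c3ccc(C(C)(C)C)cc3)N(C)C2=O)cc1` gives 46700 nM in this assay. Compound 3 `FC(F)(F)c1cc(/N=C2/NC/C(=C/c3ccccc3)S2)cc(C(F)(F)F)c1` gives 32800 nM in this assay. Of the two numbers, compound 2 stands highest; the nearest, compound 3, lies within the scatter, so no order can be read between compound 2 and compound 3. One value in the set sits at the limit of the assay, (the limit of > 100000 nM in this assay, at which 1 of the 3 values shown sits).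

Compound 4 `COc1ccc(/C=C2\S/C(=N\c3ccc(Br)cc3)N(C)C2=O)cc1` is not yet measured. It differs from compound 2 at one place: bromo in place of tert-butyl on an aromatic carbon. Going by the values given here, no measured pair in this set carries the same change, so the size of the step is not known from these compounds. The estimated step is a 1.2-fold lower number from compound 2 to compound 4 (0.07 log units; within the scatter), expected to stay within the scatter, in no particular direction. Compound 4 is expected to give 40000 nM in this assay, with a range from 15000 nM to 100000 nM.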

Compound 4, half-maximal inhibitory concentration: > 100000 nM
Compound 4: no number, only a limit; the forecaster's own chance of this, stated with the estimate: 25%; middle value at least 2.5-fold (0.39 log units) away from the limit.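

Going by these compounds alone, this aromatic carbon is not silent in this assay: bromo in place of tert-butyl gives an at least 2.1-fold higher number from compound 2 to compound 4 (0.33 log units; beyond the scatter), the first step in the set that can be read at all. The reading for compound 4 is a limit and not a number, so the step fixes only a floor on the size of the change and no upper end: the limit of > 100000 nM in this assay, at which 2 of the 4 values shown sit. Of this pair, only compound 2, with the tert-butyl group, gives a number, and a single pair cannot show which feature of the change accounts for the step.

As far as these compounds go, what chloro, an amine or a carboxylic acid would give on this carbon remains open. Also open, from the compounds shown here alone, is whether bromo in place of tert-butyl would give a step of the same direction on the core of compound 3.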